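This account rests on a few compounds, and the source may have more. Where it says the series, first, only, none or still open, it means among the compounds named here.

Going by the values given here, compound 2 `CCCCc1nc(=O)c(S(=O)(=O)c2ccc(-c3ccc(F)cc3)cc2)c(O)n1-c1c(OC)cccc1OC` gives 5% in an ADME assay on microsomes from liver (Rattus norvegicus) for metabolic stability, using NADPH, with a stated time of 10 min (on this read-out lower numbers stand for a less stable compound and higher numbers for a more stable compound), the lower of the two numbers measured so far; the only other measured compound, compound 1 `CCCCc1nc(=O)c(S(=O)(=O)c2ccc(-c3ccnc(NC(=O)C4CC4)c3)cc2)c(O)n1-c1c(OC)cccc1OC`, gives 72% in this assay. Among the compounds with values here, the single recorded step, a number 67 percentage points lower from compound 1 to compound 2 (beyond the scatter), exchanged a 2-((cyclopropylcarbonyl)amino)pyridin-4-yl for a 4-fluorophenyl on an aromatic carbon. Compound 3 `CCCCc1nc(=O)c(S(=O)(=O)c2ccc(-c3cccnc3)cc2)c(O)n1-c1c(OC)cccc1OC` differs from compound 2 by pyridin-3-yl in place of 4-fluorophenyl on an aromatic carbon. The recorded step bears on this change only in part: the 4-fluorophenyl that entered in compound 2 now leaves again, but the pyridin-3-yl that enters in compound 3 carries none of the amide that compound 1 bore. Some recovery in this assay is therefore expected, yet one clearly smaller than the large drop from compound 1 to compound 2, and with wide uncertainty. For compound 3 a value of 20% is estimated, from 4% to 50%, corresponding to an expected step of a number 15 percentage points higher from compound 2 to compound 3 (beyond the scatter).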

Compound 3, percent of the compound remaining: 3%
Beside the measured number, compound 3's estimate is 17 percentage points above it; the whole stated range lies above it.
By their numbers in this assay, from the lowest: compounds 3 and 2 (each within the scatter of the next); then compound 1.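

With the shared core unchanged, swapping the 4-fluorophenyl for a pyridin-3-yl para to a large group gives a number 2 percentage points lower from compound 2 to compound 3 (within the scatter) in this assay, so a ring nitrogen in this aryl group does not by itself separate these two compounds on this read-out. The second step, a number 69 percentage points lower from compound 1 to compound 3 (beyond the scatter), shows that among the compounds shown, a six-membered aromatic ring with 1 hetero atom at this place does not alone reproduce the number of compound 1. No measurement is available that accounts for either step.

From the compounds shown here alone, it remains open whether the higher number of compound 1 goes with the cyclopropylcarbonyl amide or with attachment through pyridin-4-yl. A plain pyridin-4-yl and a 2-aminopyridin-4-yl at this place would bear on that question.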